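The source may hold more compounds than are shown below. What is called first, only, known or untested is meant among the compounds shown, and "the series" means these compounds.

Compound 1 `COc1ccc(-c2cc(/C=C/C(=O)c3cc(OC)c(OC)c(OC)c3)[nH]n2)cc1OC`: 1970 nM
Compound 2 `COc1ccc(C(=O)/C=C/c2cc(-c3cc(OC)c(OC)c(OC)c3)n[nH]2)cc1`: 3040 nM
Compound 3 `COc1ccc(C(=O)/C=C/c2cc(-c3cc(OC)c(OC)c(OC)c3)n[nH]2)cc1OC`: 2150 nM

In a functional assay on NCI-H23 cells (Homo sapiens) for inhibition, read by sulforhodamine B assay, with a stated time of 48 h (on this read-out higher numbers stand for weaker inhibition of growth and lower numbers for stronger inhibition of growth), compound 1 gives 1970 nM, compound 2 gives 3040 nM and compound 3 gives 2150 nM. The three numbers sit close together: compound 3 lies nearest to compound 1 and farther from compound 2, yet neither gap reaches beyond the usual scatter of repeated measurements, so none of the three can be called stronger or weaker than another on this evidence.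

Compound 4 `COc1cc(C(=O)/C=C/c2cc(-c3cc(OC)c(OC)c(OC)c3)n[nH]2)cc(OC)c1OC` is not yet measured. It differs from compound 3 in a single place: methoxy in place of hydrogen on an aromatic carbon. One measured step is of the same kind, a methoxy in place of hydrogen on an aromatic carbon, and that step, a 1.4-fold lower number from compound 2 to compound 3 (0.15 log units; within the scatter), stayed within the scatter. Within the data shown here, with only this one comparison to go on, and with all three measured numbers clustered closely, no shift beyond the scatter is expected in this assay for compound 4 in either direction.

The estimate for compound 4 in this assay is therefore 2000 nM, with a range from 900 nM to 4500 nM. The step this estimate implies, a 1.1-fold lower number from compound 3 to compound 4 (0.03 log units; within the scatter), is expected to stay within the scatter.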

Compound 4, concentration for 50% growth inhibition: 3040 nM
Compound 4: middle estimate off by 1.5-fold (0.18 log units), on the low side; the measured number falls inside the stated range.
By their numbers in this assay, from the lowest: compounds 1, 3, 2 and 4 (each within the scatter of the next).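

Placing a methoxy group on this ring, ortho to a methoxy group and meta to a large group, gives a 1.4-fold higher number from compound 3 to compound 4 (0.15 log units; within the scatter) in this assay, so at this position hydrogen and methoxy cannot be told apart on this read-out. The comparison with the core of compound 1 gives a 1.5-fold higher number from compound 1 to compound 4 (0.19 log units; within the scatter), and this step also offers no sign that the added methoxy group matters. Earlier there was only one reading of this change, whereas it can now be compared on two cores, and even the gap between the two readings does not rise above the noise of the measurements: the same change on two cores in this assay, a 1.4-fold lower number (0.15 log units; within the scatter) from compound 2 to compound 3 and a 1.5-fold higher number (0.19 log units; within the scatter) from compound 1 to compound 4, 2.2-fold (0.34 log units) apart, within the scatter of two such steps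

The compounds shown leave open whether this position would respond to a different kind of group, such as an amine, a carboxylic acid or a longer chain, with a step beyond the scatter. They also leave open whether the same flat picture would hold in other cell lines, since every number here comes from a single kind of cell.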